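Shared core series: pyridin-4-yl in place of thiophen-3-yl

A few compounds are considered here, and "the series" means these few. Any claim that something is new, unique, unknown or untested is made for them only; others in the source may bear on it.

Compound 1 `COc1cc(C(=O)c2sc(-c3ccc(C)cc3)cc2N)cc(OC)c1OC` gives 16 nM in a functional assay on MOLT-4 cells (Homo sapiens) for antiproliferative activity; on this read-out lower numbers stand for stronger inhibition and higher numbers for weaker inhibition. Compound 2 `COc1cc(C(=O)c2sc(-c3ccc(Cl)c(Cl)c3)cc2N)cc(OC)c1OC` gives 270 nM in this assay, and compound 3 `COc1cc(C(=O)c2sc(-c3ccsc3)cc2N)cc(OC)c1OC` gives 8.8 nM. Compound 3 holds the lowest number of the three; compound 1 sits within the scatter of it, so no order between those two is claimed, whereas compound 2 lies far off: a 31-fold lower number from compound 2 to compound 3 (1.49 log units; beyond the scatter). Compound 4 `COc1cc(C(=O)c2sc(-c3ccncc3)cc2N)cc(OC)c1OC` carries pyridin-4-yl in place of thiophen-3-yl on an aromatic carbon. The relevant steps are the other exchanges on that aromatic carbon, a 1.8-fold lower number from compound 1 to compound 3 (0.26 log units; within the scatter) and a 31-fold lower number from compound 2 to compound 3 (1.49 log units; beyond the scatter): two groups gave close numbers, one gave a large rise. A moderate rise in the number is therefore expected for compound 4, a 5.7-fold higher number from compound 3 to compound 4 (0.75 log units; beyond the scatter). Compound 4 is estimated at 50 nM, within 10 nM to 300 nM.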

Compound 4, half-maximal inhibitory concentration: 88 nM
For compound 4 the middle estimate is 1.8-fold (0.25 log units) below the measured one; measured number inside the range.
By their numbers in this assay, from the lowest: compounds 3 and 1 (each within the scatter of the next); then compound 4; then compound 2.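

In this assay, the aromatic carbon next to the ring sulfur distinguishes between two aromatic rings with one hetero atom each (a 10-fold higher number from compound 3 to compound 4 (1.00 log units; beyond the scatter)), although thiophen-3-yl and pyridin-4-yl share the same acceptor count and no net charge. Pyridin-4-yl also stands apart from both phenyl groups (a 5.5-fold higher number from compound 1 to compound 4 (0.74 log units; beyond the scatter); a 3.1-fold lower number from compound 2 to compound 4 (0.49 log units; beyond the scatter)), so this position now shows an intermediate level as well as close numbers and one large rise. No measurement shown accounts for the rise from thiophen-3-yl to pyridin-4-yl.

Open, going by these compounds, is whether the rise follows the ring nitrogen's location, which pyridin-3-yl or pyridin-2-yl on the same carbon would test. Also open, on these data alone, is how thiophen-2-yl or furan-3-yl compares with thiophen-3-yl.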